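This account rests on a few compounds, and the source may have more. Where it says the series, first, only, none or still open, it means among the compounds named here.

Compound 1 `O=S(=O)(c1cc(F)cc(F)c1)c1cnc2c(F)cccc2c1-c1ccccc1F`, compound 2 `COc1ccc(-c2c(S(=O)(=O)c3cc(F)cc(F)c3)cnc3c(F)cccc23)cc1` and compound 3 `COc1ccc(-c2c(S(=O)(=O)c3cc(Cl)cc(Cl)c3)cnc3c(F)cccc23)cc1` have been measured. In an ADME assay on microsomes from liver (Homo sapiens) for metabolic stability, tested at 2.5 uM (a lower number here means slower removal, a higher number faster removal of the compound), compound 1 gives 0.09 mL/min, compound 2 gives 2.59 mL/min and compound 3 gives 2.11 mL/min.

Compound 4 `O=S(=O)(c1cc(Cl)cc(Cl)c1)c1cnc2c(F)cccc2c1-c1ccccc1F` has not yet been measured. It differs from compound 3 in one place: 2-fluorophenyl in place of 4-methoxyphenyl on an aromatic carbon. The same change has been made once before among these compounds, (2-fluorophenyl in place of 4-methoxyphenyl on an aromatic carbon), and in this assay it brought a 29-fold lower number from compound 2 to compound 1 (1.46 log units; beyond the scatter). The place of the change is described in identical words for both pairs, so it counts as the same change, not merely one of the same kind. The cores on which it is made differ in 3,5-dichlorophenyl in place of 3,5-difluorophenyl on a sulfonyl sulfur, a change that in this assay brought a 1.2-fold lower number from compound 2 to compound 3 (0.09 log units; within the scatter).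

Compound 4 is therefore expected to show a 26-fold lower number from compound 3 to compound 4 (1.42 log units; beyond the scatter) because a 29-fold lower number from compound 2 to compound 1 (1.46 log units; beyond the scatter), a step that stands well beyond the scatter, while the core difference brought only a 1.2-fold lower number from compound 2 to compound 3 (0.09 log units; within the scatter). Compound 4 is estimated at 0.08 mL/min, with a likely range from 0.03 mL/min to 0.25 mL/min.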

Compound 4, intrinsic clearance in a liver preparation (reported as CLH), per the amount of preparation that the assay uses: 0.44 mL/min
For compound 4 the middle estimate is 5.5-fold (0.74 log units) below the measured one, and the stated range ends below it.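

In this assay, putting 2-fluorophenyl in place of 4-methoxyphenyl on the core with 3,5-dichlorophenyl brought a 4.8-fold lower number from compound 3 to compound 4 (0.68 log units; beyond the scatter), so the direction of the earlier step carried over but its size did not: the same change on two cores in this assay, a 29-fold lower number (1.46 log units; beyond the scatter) from compound 2 to compound 1 and a 4.8-fold lower number (0.68 log units; beyond the scatter) from compound 3 to compound 4, 6.0-fold (0.78 log units) apart, beyond the scatter of two such steps

Read the other way, the swap of 3,5-difluorophenyl for 3,5-dichlorophenyl brought a 1.2-fold lower number from compound 2 to compound 3 (0.09 log units; within the scatter) with 4-methoxyphenyl present, yet a 4.9-fold higher number from compound 1 to compound 4 (0.69 log units; beyond the scatter) with 2-fluorophenyl present: the same change on two cores in this assay, a 1.2-fold lower number (0.09 log units; within the scatter) from compound 2 to compound 3 and a 4.9-fold higher number (0.69 log units; beyond the scatter) from compound 1 to compound 4, 6.0-fold (0.78 log units) apart, beyond the scatter of two such steps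

In these four compounds, then, the effect of each change depends on the group at the other place, so a step measured on one core gives the direction on the other but not a safe size, although the numbers do not show why the two steps differ or whether this holds beyond these compounds.

From the compounds shown here alone, it remains open how the other groups would behave if an amine or a carboxylic acid stood in place of the 2-fluorophenyl. Going by these compounds, it also remains open whether a sulfonyl partner other than these two 3,5-dihalophenyl groups would show the same dependence.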